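Cytotoxicity at the assay limit across three aryl variants

A few compounds are considered here, and "the series" means these few. Any claim that something is new, unique, unknown or untested is made for them only; others in the source may bear on it.

Compound 1 `CC(C)N(Cc1cccc(OCCCCCC(=O)O)c1)C(=O)c1ccc(-c2cccc3ccccc23)cc1`: > 26000 nM
Compound 2 `CC(=O)c1cccc(-c2ccc(C(=O)N(Cc3cccc(OCCCCCC(=O)O)c3)C(C)C)cc2)c1`: > 26000 nM
Compound 3 `CC(C)N(Cc1cccc(OCCCCCC(=O)O)c1)C(=O)c1ccc(-c2cccc(OCc3ccccc3)c2)cc1`: > 26000 nM

All three compounds share one core and were tested in an ADME assay on HEK293 cells (Homo sapiens) for cytotoxicity, read by CellTiter-Glo and resazurin assay, with a stated time of 72 h; a lower number here means that less compound is needed, a higher number that more compound is needed for the effect. Compound 1 gives > 26000 nM, which is a limit of the assay and not a number. Compound 2 likewise stops at the limit > 26000 nM. Compound 3 also stops at the limit > 26000 nM. The two steps among them, a step that the two limits leave unreadable from compound 1 to compound 2 and a step that the two limits leave unreadable from compound 2 to compound 3, cannot be read in size or direction, because the limit of > 26000 nM in this assay, at which 3 of the 3 values shown sit, leaves no number on either side of either step.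

Compound 4 `Cc1nnc(-c2cccc(-c3ccc(C(=O)N(Cc4cccc(OCCCCCC(=O)O)c4)C(C)C)cc3)c2)o1` is not yet measured. It differs from compound 1 in one place: 3-(5-methyl-1,3,4-oxadiazol-2-yl)phenyl in place of naphthalen-1-yl on an aromatic carbon. Among the measured compounds shown here, no measured step bears on this change in a readable way, so the expectation for compound 4 rests on where compound 1 stands, at the limit > 26000 nM. Compound 4 is therefore expected to give 26000 nM, within 13000 nM to 60000 nM, and most likely to be reported again only as a limit. The expected step is a number no higher from compound 1 to compound 4 (the limit leaves the size open), none beyond the scatter in this assay.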

Compound 4, half-maximal effective concentration: > 26000 nM
Compound 4 ended at the assay's limit; the forecaster's own chance of this, stated with the estimate: 85%; the middle value lies on the limit itself.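

In this assay compound 4 gives > 26000 nM, which is a limit of the assay and not a number. No step joining compound 4 to compound 1, compound 2 or compound 3 can be read in size or direction, because all four stop at the same point: the limit of > 26000 nM in this assay, at which 4 of the 4 values shown sit.

The compounds shown leave open what concentration of any of them would give the half-maximal effect, and so whether the exchanged groups differ at all.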